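A few compounds are considered here, and "the series" means these few. Any claim that something is new, unique, unknown or untested is made for them only; others in the source may bear on it.

Measured so far in a functional assay on HCT-116 cells (Homo sapiens) for cytotoxicity, read by MTT assay; on this read-out higher numbers stand for weaker inhibition and lower numbers for stronger inhibition:

Compound 1 `CCn1cc(C(=O)Nc2ccccc2N)c(=O)c2cc(F)c(N3CCNC(C)C3)c(F)c21` gives 2700 nM
Compound 2 `CCn1cc(C(=O)Nc2cccc([N+](=O)[O-])c2)c(=O)c2cc(F)c(N3CCNC(C)C3)c(F)c21` gives 2710 nM

These two numbers lie within the usual scatter of each other, so compound 2 stands level with compound 1 and neither can be ranked above the other. Still unmeasured is compound 3 `CCn1cc(C(=O)Nc2ccc(OC(F)(F)F)cc2)c(=O)c2cc(F)c(N3CCNC(C)C3)c(F)c21` and its difference from compound 2 is 4-(trifluoromethoxy)phenyl in place of 3-nitrophenyl on an amide-type nitrogen in short, 4-(trifluoromethoxy)phenyl in place of 3-nitrophenyl on an amide-type nitrogen.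

Within the data shown here, only one measured step bears on this change, and it also swaps the group on that amide-type nitrogen. That swap, 3-nitrophenyl in place of 2-aminophenyl, gave a step (a 1.0-fold higher number from compound 1 to compound 2 (0.00 log units; within the scatter)) that stays within the scatter, so no step beyond the scatter is expected in this assay in either direction. Among the measured compounds shown here, one step is thin evidence, and no measured compound carries the 4-(trifluoromethoxy)phenyl group, so the range has to stay wide. The estimated change is (a 1.1-fold lower number from compound 2 to compound 3 (0.04 log units; within the scatter)) and so remains small. For compound 3 the estimated value is 2500 nM with an expected range from 900 nM to 7000 nM in this read-out.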

Compound 3, half-maximal inhibitory concentration: 2350 nM
The estimate for compound 3 lay 1.1-fold (0.03 log units) above the measured number; low and high end bracket the measured number.
By their numbers in this assay, from the lowest: compounds 3, 1 and 2 (each within the scatter of the next).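

In this assay the amide-type nitrogen now carries a third aromatic group, 4-(trifluoromethoxy)phenyl, and the two new steps (a 1.2-fold lower number from compound 2 to compound 3 (0.06 log units; within the scatter)) and (a 1.1-fold lower number from compound 1 to compound 3 (0.06 log units; within the scatter)) leave all three compounds level with one another. Among these compounds, this goes further than the single earlier step: 4-(trifluoromethoxy)phenyl shares only its six-membered aromatic ring of carbon with 3-nitrophenyl, bringing 11 heavy atoms in place of 9, 3 fluorine atoms and no nitrogen, and 1 hydrogen-bond acceptor in place of 2, yet the number stays within the scatter. Nothing measured here explains why these swaps on this nitrogen leave the number level.

Going by these compounds, all three compounds carry a substituted phenyl ring on this nitrogen, so it remains open whether a plain alkyl chain, a cyclohexyl ring or a phenyl ring bearing a carboxylic acid would give a step beyond the scatter. The rest of the shared core is identical across the three compounds, so they say nothing about how changes elsewhere in the molecule would affect the number.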